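This account rests on a few compounds, and the source may have more. Where it says the series, first, only, none or still open, it means among the compounds named here.

In a functional assay on the whole organism with Rattus norvegicus as the target (a higher number here means that more compound is needed for the effect, a lower number that less compound is needed), compound 1 `CCCCCc1ccc2nc(N)sc2c1` gives 7.5 mg/kg, and compound 2 `CCCCCCc1ccc2nc(N)sc2c1` gives 7 mg/kg. The change between them, (methyl in place of hydrogen on a saturated chain carbon, five bonds along the chain from an aromatic carbon), gave a 1.1-fold lower number from compound 1 to compound 2 (0.03 log units; within the scatter). Compound 3 `CCSCCn1c(=N)sc2cc(OC(F)(F)F)ccc21` rests on another core; the difference between the two cores is not broken down here. In this assay compound 3 gives 2.2 mg/kg, the lowest of the three numbers. Compound 4 `CCCSCCn1c(=N)sc2cc(OC(F)(F)F)ccc21` has not yet been measured; it differs from compound 3 by methyl in place of hydrogen on a saturated chain carbon, two bonds along the chain from a sulfur. This is the same kind of change as from compound 1 to compound 2, though there the methyl enters five bonds along the chain from an aromatic carbon, whereas here it enters two bonds along the chain from a sulfur. Because a 1.1-fold lower number from compound 1 to compound 2 (0.03 log units; within the scatter) stayed within the scatter, a step of similar size, a 1.1-fold lower number from compound 3 to compound 4 (0.04 log units; within the scatter), is expected. Compound 4 is therefore estimated at 2 mg/kg in this assay, with a likely range from 1 mg/kg to 4.5 mg/kg.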

Compound 4, dose for half-maximal effect: 2.4 mg/kg
For compound 4 the middle estimate is 1.2-fold (0.08 log units) below the measured one; measured number inside the range.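

In this assay, the methyl that turns ethylsulfanyl into propylsulfanyl gave a 1.1-fold higher number from compound 3 to compound 4 (0.04 log units; within the scatter), so the longer chain made no real difference on this core. The same change was just as flat on the core of compound 1, and the two steps agree: the same change on two cores in this assay, a 1.1-fold lower number (0.03 log units; within the scatter) from compound 1 to compound 2 and a 1.1-fold higher number (0.04 log units; within the scatter) from compound 3 to compound 4, 1.2-fold (0.07 log units) apart, within the scatter of two such steps. This shows that a one-carbon extension of these chains carried over without a visible effect on these two cores, but two flat steps cannot show that a larger effect would carry over, or that other cores would behave the same way.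

The compounds shown leave open what a much longer chain, an amine or a carboxylic acid would do in place of this methyl. They also cannot separate the effects of the several differences between the two cores.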